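The source may hold more compounds than are shown below. What is called first, only, known or untested is meant among the compounds shown, and "the series" means these compounds.

- compound 1 `C=C(Br)C(=O)Nc1cccc(/C=C/C(=O)Nc2ccccc2)c1` gives 190 nM in a functional assay on CCRF-CEM cells (Homo sapiens) for inhibition, read by MTT assay, with a stated time of 72 h; on this read-out lower numbers stand for stronger inhibition and higher numbers for weaker inhibition
- compound 2 `C=C(Br)C(=O)Nc1cccc(/C=C/C(=O)Nc2ccc(F)c(F)c2)c1` gives 13 nM in this assay

Compound 1 has the higher of these two numbers, so it is the weaker inhibitor of the pair in this assay. Compound 3 `C=C(Br)C(=O)Nc1cccc(/C=C/C(=O)Nc2ccc(OCC)cc2)c1` has not yet been measured. It differs from compound 1 by ethoxy in place of hydrogen on an aromatic carbon, which means ethoxy in place of hydrogen on an aromatic carbon, para to a large group. For the measured compounds named here, only one measured step bears on this change, and it is large: a 15-fold lower number from compound 1 to compound 2 (1.16 log units; beyond the scatter), with 3,4-difluorophenyl in place of phenyl on an amide-type nitrogen. That step involves a different group, so it is only a loose guide. A smaller change in the same direction therefore seems reasonable. The expected result is a 2.7-fold lower number from compound 1 to compound 3 (0.43 log units; beyond the scatter), though a change within the scatter remains possible. For compound 3, the estimated value is 70 nM, with an expected range from 15 nM to 300 nM.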

Compound 3, half-maximal inhibitory concentration: 98 nM
For compound 3 the middle estimate is 1.4-fold (0.15 log units) below the measured one; the range from low to high includes it.
By their numbers in this assay, from the lowest: compound 2; then compounds 3 and 1 (each within the scatter of the next).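

In this assay ethoxy in place of hydrogen on an aromatic carbon, para to a large group, gives a 1.9-fold lower number from compound 1 to compound 3 (0.29 log units; within the scatter) and so leaves compound 3 indistinguishable from compound 1 on this read-out. For the compounds shown here, the earlier pair showed only that changing this ring can matter a great deal, as in a 15-fold lower number from compound 1 to compound 2 (1.16 log units; beyond the scatter) with 3,4-difluorophenyl in place of phenyl; the new result adds that this ring position accepts an ethoxy group with no clear loss or gain in cell inhibition. No measurement here explains why the two changes on this ring differ so much in size.

As far as these compounds go, whether methoxy, a longer chain such as butoxy, or an amine at this position would also stay within the scatter remains open. So does the effect of a single fluorine on this ring.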